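Carboxy in Place of Phenyl in a Series

This account rests on a few compounds, and the source may have more. Where it says the series, first, only, none or still open, it means among the compounds named here.

Going by the values given here, compound 3 `CC1(C)CC(=O)C2=C(C1)NC(c1ccccc1)=CC2c1ccc(F)cc1` is the only member of this set with a number attached. In an assay on isolated protein for inhibition of glucose-6-phosphatase catalytic subunit 1 (Homo sapiens), read by inositol phosphate accumulation, with a stated time of 30 min, tested at 100 uM (a lower number here means less inhibition, a higher number more inhibition at the concentration tested (going by the name of the read-out)), compound 3 gives 7.38%. Compound 1 `CC1(C)CC(=O)C2=C(C1)NC(c1ccccc1)=CC2c1ccc([N+](=O)[O-])cc1` is reported as "not active" (no number reported), and compound 2 `COc1ccc(C2C=C(c3ccccc3)NC3=C2C(=O)CC(C)(C)C3)cc1` likewise as "not active" (no number reported), so compound 3 stands alone with a measured figure, and that figure is small. Compound 4 `CC1(C)CC(=O)C2=C(C1)NC(C(=O)O)=CC2c1ccc(F)cc1` has not yet been measured. It differs from compound 3 by carboxy in place of phenyl on a double-bonded ring carbon. Among the compounds with values here, no pair of measured compounds differs in a single place, so no measured step guides the expectation; compounds 1 and 2, which keep the phenyl, show no reportable inhibition either. The step of a number 2.4 percentage points lower from compound 3 to compound 4 (within the scatter) is therefore expected to be none beyond the scatter. Compound 4 is estimated at 5%, in the range -10% to 20%.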

Compound 4, a percentage reported as inhibition, at one concentration (the size of the read-out at that concentration, not a potency): 16.8%
Estimate against measurement, compound 4: 11.8 percentage points below; the measured number falls inside the stated range.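

In this assay, carboxy in place of phenyl on a double-bonded ring carbon gives a number 9.4 percentage points higher from compound 3 to compound 4 (within the scatter). At this position, then, the six-membered aromatic ring can give way to a group with no ring without the read-out moving beyond the scatter. No measurement is at hand that would explain this result. As far as these compounds go, whether a carboxamide, a methyl ester or an amine on the same ring carbon would read any differently stays open. So does whether carboxy would give a similar reading on the cores of compound 1 and compound 2.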